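A few compounds are considered here, and "the series" means these few. Any claim that something is new, unique, unknown or untested is made for them only; others in the source may bear on it.

Measured compounds, with their values in a functional assay on U-937 cells (Homo sapiens) for cytotoxicity, read by MTT assay, with a stated time of 24 h; on this read-out lower numbers stand for stronger inhibition and higher numbers for weaker inhibition:

Compound 1 `CCCCCCCCCCn1cc(Cn2c(C)nc3nc(-c4ccccc4)cc(C(F)(F)F)c3c2=O)nn1` gives 6.2 ug/mL.
Compound 3 `CCCCCCCCCCn1cc(Cn2c(CC)nc3nc(-c4ccccc4)cc(C(F)(F)F)c3c2=O)nn1` gives 17.8 ug/mL.
Compound 2 `CCc1nc2nc(-c3ccccc3)cc(C(F)(F)F)c2c(=O)n1Cc1cn(CCC(F)(F)C(F)(F)C(F)(F)C(F)(F)C(F)(F)C(F)(F)C(F)(F)C(F)(F)F)nn1` reaches only the limit of the assay, > 200 ug/mL, and no number.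

Compound 1 and compound 3 share one core and differ at a single place: methyl in place of hydrogen on a saturated chain carbon bound to an aromatic carbon. That change gives a 2.9-fold higher number from compound 1 to compound 3 (0.46 log units; beyond the scatter). The difference between the core of compound 1 and the core of compound 2 is not broken down here. Compound 2 sits at a limit, a fact to keep in view: the limit of > 200 ug/mL in this assay, at which 1 of the 3 values shown sits.

Compound 4 `CC(C)c1nc2nc(-c3ccccc3)cc(C(F)(F)F)c2c(=O)n1Cc1cn(CCC(F)(F)C(F)(F)C(F)(F)C(F)(F)C(F)(F)C(F)(F)C(F)(F)C(F)(F)F)nn1` is not yet measured. It differs from compound 2 in one place: methyl in place of hydrogen on a saturated chain carbon bound to an aromatic carbon and a saturated chain carbon. Among the compounds with values here, this is the same kind of change as the one from compound 1 to compound 3, not the same change; around the place, the carbon that carries the new methyl is bound to an aromatic carbon and a saturated chain carbon in compound 4, while in compound 3 it is bound to an aromatic carbon only.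

In this assay the step from compound 2 to compound 4 is expected to be a step that the limit leaves unreadable from compound 2 to compound 4, set beside the measured step of a 2.9-fold higher number from compound 1 to compound 3 (0.46 log units; beyond the scatter), which went toward a higher number; with compound 2 already at the limit of the assay, compound 4 is estimated to remain at or beyond that limit. Compound 4 is estimated at 400 ug/mL, with a range from 150 ug/mL to 1500 ug/mL.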

Compound 4, half-maximal inhibitory concentration: 8.35 ug/mL
Beside the measured number, compound 4's estimate is 48-fold (1.68 log units) above it; the measured number lies below the stated range.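

In this assay, methyl in place of hydrogen gives an at least 23-fold lower number from compound 2 to compound 4 (1.37 log units; beyond the scatter), whereas on the core of compound 1 the same kind of change gives a 2.9-fold higher number from compound 1 to compound 3 (0.46 log units; beyond the scatter). The direction of this change therefore does not carry from one core to the other in these two pairs: the same change on two cores in this assay, a 2.9-fold higher number (0.46 log units; beyond the scatter) from compound 1 to compound 3 and an at least 23-fold lower number (1.37 log units; beyond the scatter) from compound 2 to compound 4, at least 68-fold (1.83 log units) apart, beyond the scatter of two such steps

Compound 2 has only a limit of the assay, > 200 ug/mL, so the true size of that step stays unread, and two pairs give neither a reason for the reversal nor a rule for any further core.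

The compounds shown leave open whether the reversal follows the core or the carbon that carries the new methyl, which is bound to an aromatic carbon and a saturated chain carbon in compound 4 but to an aromatic carbon only in compound 3. Also open, from the compounds shown here alone, are how isopropyl would read on the core of compound 1, and how a longer chain such as propyl or an amine at the same place would read on either core.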